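Amine side chain swap in a sulfamate series

A few compounds are considered here, and "the series" means these few. Any claim that something is new, unique, unknown or untested is made for them only; others in the source may bear on it.

Two sulfamates have been measured in an assay on HEK293 cells for inhibition of Steryl-sulfatase (Homo sapiens), tested at 0.1 uM; a lower number here means a weaker effect, a higher number a stronger effect of the compound at the concentration tested. Compound 1 `CN(CCN1CCCCC1)c1ccc(C(=O)N2CCc3ccc(OS(N)(=O)=O)cc3C2)cc1` gives 0.3%, while compound 2 `CN(CCCN1CCCCC1)c1cccc(C(=O)N2CCc3ccc(OS(N)(=O)=O)cc3C2)c1` gives 24.1%, the higher of the two numbers, and the gap between them lies beyond the usual scatter. Compound 3 `CCN(Cc1cccnc1)c1cccc(C(=O)N2CCc3ccc(OS(N)(=O)=O)cc3C2)c1` has not been measured; it differs from compound 2 in one place: ethyl((pyridin-3-yl)methyl)amino in place of methyl(3-(piperidin-1-yl)propyl)amino on an aromatic carbon. For the measured compounds named here, no step between measured compounds covers this change, so only a small downward step, a number 9.1 percentage points lower from compound 2 to compound 3 (within the scatter), or none beyond the scatter is expected. Compound 3 is therefore estimated at 15% in this assay, within a range from 0% to 40%.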

Compound 3, a percentage reported as inhibition, at one concentration (the size of the read-out at that concentration, not a potency): 14.3%
Beside the measured number, compound 3's estimate is 0.7 percentage points above it, and the stated range covers the measured number.
By their numbers in this assay, from the lowest: compound 1; then compounds 3 and 2 (each within the scatter of the next).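

Replacing methyl(3-(piperidin-1-yl)propyl)amino with ethyl((pyridin-3-yl)methyl)amino on this aromatic carbon gives a number 9.8 percentage points lower from compound 2 to compound 3 (within the scatter) in this assay and so no difference beyond the scatter. At this place, meta to a large group, a six-membered non-aromatic ring at the end of a chain and a six-membered aromatic ring with one hetero atom therefore read alike, a point that the two earlier compounds, which differ in more than one place, could not show. As far as these compounds go, whether a carboxylic acid or a morpholine ring on this carbon would move the number beyond the scatter stays open. No measurement at hand bears on what lies behind this result.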